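The source may report more compounds than this note shows. Statements on the series, on what has been measured and on what is new or still open speak of the compounds shown alone.

Values in a physicochemical assay for lipophilicity, read by HPLC, measured as chromatographic lipophilicity, at pH 7.4; on this read-out lower numbers stand for lower lipophilicity and higher numbers for higher lipophilicity:

compound 1 `CC(C)(C)C(=O)N1CCSC1c1ccccc1`: 5.6
compound 2 `CCC(=O)N1CCC(C(=O)N2N=CCC2c2ccccc2)CC1`: 3.2
compound 3 `Cc1nnc(N2CCC(C(=O)N3N=CC[C@H]3c3cc(F)cc(F)c3)CC2)o1`: 3.6

Lipophilicity describes how strongly a compound favours a greasy environment over water, and small edits to a molecule can shift it. Among these three measurements, compound 2 gives 3.2, the lowest number. Compound 3 stands nearest at 3.6, a gap beyond the usual scatter, while compound 1 lies furthest away at 5.6.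

The next compound to be measured is compound 4 `O=C(c1cocn1)N1CCC(C(=O)N2N=CCC2c2ccccc2)CC1`, which keeps most of compound 2 and changes one group. The change is 1,3-oxazol-4-yl in place of ethyl on a carbonyl carbon. In other words, 1,3-oxazol-4-yl takes the place of ethyl on a carbonyl carbon, so propanoyl becomes (1,3-oxazol-4-yl)carbonyl.

Among the measured compounds shown here, none of the measured compounds forms a pair that differs in only one place, so the data offer no direct measure of this exchange. Compound 3 differs from compound 2 in more than one place, and compound 3 with its value of 3.6 serves only as a loose guide to the neighbourhood. A small upward step is expected, a number 0.20 log units higher from compound 2 to compound 4 (within the scatter), no larger than the usual scatter.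

For compound 4 the expected value is 3.4, with an estimated range from 2.9 to 3.9.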

Compound 4, distribution coefficient: 2.9
Compound 4: middle estimate off by 0.50 log units, on the high side, and the stated range covers the measured number.
By their numbers in this assay, from the lowest: compounds 4 and 2 (each within the scatter of the next); then compound 3; then compound 1.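

In this assay, among the compounds shown here, the pair gives the first direct reading at this position, where 1,3-oxazol-4-yl takes the place of ethyl on a carbonyl carbon (a number 0.30 log units lower from compound 2 to compound 4 (within the scatter)). The change is far from trivial on paper: 2 heavy atoms with no ring leave, and 5 heavy atoms enter, with one five-membered aromatic ring and 2 hydrogen-bond acceptors. Even so, the two compounds cannot be told apart on this read-out, so this single exchange at this position leaves the number within the usual scatter, and no measurement available here bears on why.

The compounds shown leave open whether other groups on this carbonyl carbon, such as a longer chain like butyl, a dimethylamino group or a phenyl ring, would also stay within the scatter of compound 2 or would move the number clearly. One pair also cannot say whether the same exchange would give a similar reading on a different core, such as that of compound 1 or compound 3.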